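The source may report more compounds than this note shows. Statements on the series, on what has been measured and on what is new or still open speak of the compounds shown alone.

Compound 3, with the structure `COC(=O)C1=C(C)N(c2ccccc2)C=C(C)C1c1ccccc1`, is measured in a functional assay, tested at 100 ug/mL (on this read-out lower numbers stand for a stronger effect and higher numbers for a weaker effect at the one concentration tested), where compound 3 gives -14.1%. Among the three numbers measured, this is the second highest. Compound 2, with the structure `COC(=O)C1=C(C)N(c2ccc(OC)cc2)C=C(C)C1c1ccccc1`, gives -13.9%, and the difference a number 0.2 percentage points lower from compound 2 to compound 3 (within the scatter) is one the assay cannot tell apart from a repeat measurement. Compound 1, with the structure `COC(=O)C1=C(C)N(c2ccccc2)C=CC1c1ccccc1`, gives -26.9%, and the step of a number 12.8 percentage points higher from compound 1 to compound 3 (beyond the scatter) is the only one here that stands out of the scatter.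

Compound 4, with the structure `COC(=O)C1=C(C)N(c2cccc(Cl)c2)C=C(C)C1c1ccccc1`, differs from compound 3 in one place: chloro in place of hydrogen on an aromatic carbon. Among the compounds with values here, the measured step that bears on this most directly is the one between compound 2 and compound 3, where changing a group on an aromatic carbon moved the read-out by a number 0.2 percentage points lower from compound 2 to compound 3 (within the scatter). The other measured step sits on a different part of the core, a double-bonded ring carbon, and says little about a change on the aromatic ring. On this basis the step of a number 0.1 percentage points higher from compound 3 to compound 4 (within the scatter) is expected to stay within the scatter, and compound 4 is estimated at -14%, with a range from -28% to 0%.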

Compound 4, a percentage reported as activity, at one concentration (the size of the read-out at that concentration, not a potency): -12%
For compound 4 the middle estimate is 2 percentage points below the measured one; the measured number falls inside the stated range.
By their numbers in this assay, from the lowest: compound 1; then compounds 3, 2 and 4 (each within the scatter of the next).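

Replacing phenyl with 3-chlorophenyl on the ring nitrogen gives a number 2.1 percentage points higher from compound 3 to compound 4 (within the scatter), so in this assay chloro at this spot on the aromatic ring leaves the read-out inside the scatter. Exchanging the whole substituted ring gives a number 1.9 percentage points higher from compound 2 to compound 4 (within the scatter), which means that the 3-chlorophenyl of compound 4, the 4-methoxyphenyl of compound 2 and the plain phenyl of compound 3 cannot be told apart at the one concentration tested. This tolerance so far covers only these three rings, and nothing available explains it.

As far as these compounds go, whether a charged group such as an amine or a carboxylic acid on this ring would shift the read-out remains open. So does whether a larger substituent, such as a longer carbon chain, would behave like chloro.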